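The compounds below may be only part of what the source reports. "The series", "measured", "known", "first", "only" and "open" are said of these compounds alone.

Working notes on the series. Three compounds sharing one core have been run in a physicochemical assay for solubility, read by nephelometry, measured as kinetic solubility, at pH 2; a higher number here means a more soluble compound, a lower number a less soluble compound. Compound 1 is `COc1ccc(-c2cc(-c3cccc(S(C)(=O)=O)c3)cnc2N)cn1`, compound 2 is `COc1ccc(-c2cc(-c3ccc(S(N)(=O)=O)cc3)cnc2N)cn1` and compound 3 is `COc1ccc(-c2cc(-c3ccc(S(C)(=O)=O)c(F)c3)cnc2N)cn1`. In this assay compound 1 reaches only the assay limit of > 100 ug/mL. Compound 2 likewise stands at the limit, reading > 100 ug/mL in this assay. For compound 3 the result is also a limit, > 100 ug/mL. Going by the values given here, every value so far therefore sits at the limit of > 100 ug/mL in this assay, at which 3 of the 3 values shown sit, and compound 2 cannot be placed against compound 1 or compound 3 beyond saying that all three reach the same limit. Among the compounds with values here, no step between measured compounds is available, so the series gives no measured size for any structural change.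

Compound 4 is `COc1ccc(-c2cc(-c3ccc(-n4cccn4)cc3)cnc2N)cn1`, not yet measured in this assay. Relative to compound 2 the change is 1H-pyrazol-1-yl in place of sulfamoyl on an aromatic carbon. Within the data shown here, the series offers only limits, so there is no measured step to lean on. The expected step is an at least 1.1-fold lower number from compound 2 to compound 4 (0.04 log units; that floor lies within the scatter), most likely nothing beyond the scatter and a result again at the limit, with some chance of a reading just under it. For compound 4 the estimate in this assay is 90 ug/mL, between 25 ug/mL and 150 ug/mL.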

Compound 4, solubility: > 100 ug/mL
Compound 4 gave a limit, no number (the forecaster's own chance of this, stated with the estimate: 60%); middle value at least 1.1-fold (0.04 log units) from the limit.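

In this assay compound 4 gives > 100 ug/mL and this is a limit, not a number. No step can be read between compound 2 and compound 4, since both sit at the same limit: the limit of > 100 ug/mL in this assay, at which 4 of the 4 values shown sit. The compounds shown leave open whether 1H-pyrazol-1-yl in place of sulfamoyl shifts the true solubility at all.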